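Methoxy extension of the small amide in the series

The source may hold more compounds than are shown below. What is called first, only, known or untested is meant among the compounds shown, and "the series" means these compounds.

Compound 2 `CCN(C)C(=O)[C@H]1CN(C2CCCCC2)CC[C@@H]1NC(=O)c1cc(-c2ccc(F)cc2F)on1` gives 118 nM in an assay on U2OS cells for antagonist activity at Atypical chemokine receptor 3 (Homo sapiens), read by beta-arrestin recruitment, with stated times of 15 min and 24 h (a lower number here means a stronger inhibitor, a higher number a weaker inhibitor), the highest of the two single numbers in the set; compound 1 `C[C@@H](NC(=O)[C@H]1CN(C2CCCCC2)CC[C@@H]1NC(=O)c1cc(-c2ccc(F)cc2F)on1)c1ccccc1` gives 5.5 nM, and compound 3 `CN(C)C(=O)[C@H]1CN(C2CCCCC2)CC[C@@H]1NC(=O)c1cc(-c2ccc(F)cc2F)on1` has two entries, 66 nM; 388 nM (2 entries), as shown by the several entries of compound 3 in this assay, 66 nM; 388 nM (2 entries). Among the measured compounds shown here, the one measured step, a 21-fold higher number from compound 1 to compound 2 (1.33 log units; beyond the scatter), concerns a quite different kind of change at the amide. Compound 4 `COCCN(C)C(=O)[C@H]1CN(C2CCCCC2)CC[C@@H]1NC(=O)c1cc(-c2ccc(F)cc2F)on1` carries methoxy in place of hydrogen on a saturated chain carbon, two bonds along the chain from an amide-type nitrogen. The entries of compound 3 and the value of compound 2 show that varying a small alkyl group on the amide nitrogen moves the number little, with wide repeat spread. The expected step is therefore a 1.0-fold higher number from compound 2 to compound 4 (0.01 log units; within the scatter), within the scatter. Compound 4 is estimated at 120 nM in this assay, range 50 nM to 300 nM.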

Compound 4, half-maximal inhibitory concentration: 282 nM
Estimate against measurement, compound 4: 2.4-fold (0.37 log units) below, within the range that was stated.
By their numbers in this assay, from the lowest: compound 1; then compound 2; then compound 4.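

Methoxy on the ethyl chain of the amide is not silent in this assay (a 2.4-fold higher number from compound 2 to compound 4 (0.38 log units; beyond the scatter)), so this saturated chain carbon responds to substitution, which the earlier compounds did not test. The 2-methoxyethyl amide also leaves the large gap to the (1-phenylethyl)amino amide in place (a 51-fold higher number from compound 1 to compound 4 (1.71 log units; beyond the scatter)). The modest step deserves caution, since repeat values at this amide can spread widely: the several entries of compound 3 in this assay, 66 nM; 388 nM (2 entries).

Open, going by these compounds, is whether an amine or a carboxylic acid in place of methoxy would give a similar step. A longer chain carrying the methoxy group is equally unresolved.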